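Carboxy for methoxy on the aryl ring: tolerance notes

The source may report more compounds than this note shows. Statements on the series, on what has been measured and on what is new or still open speak of the compounds shown alone.

Measured so far:
- compound 1, `CCOC(=O)c1cn(-c2ccc(C(=O)O)cc2)nc1CC(C)C`: > 100000 nM
- compound 2, `CCOC(=O)c1cn(-c2ccc(OC)cc2)nc1CC(C)C`: 77100 nM
- compound 3, `CCOC(=O)c1cn(-c2cccc(OC)c2)nc1CC(C)C`: 70500 nM

All three share a common core and differ only in the substituent on the aryl ring attached to it. In a toxicity assay on HepG2 2.2.15 cells (Homo sapiens) for cytotoxicity, read by CCK-8 assay, with a stated time of 8 days (a higher number here means that more compound is tolerated, a lower number that less compound is tolerated), compound 1 reaches only a limit of the assay, (the limit of > 100000 nM in this assay, at which 1 of the 3 values shown sits), and no number is obtained. Compound 2 gives 77100 nM in this assay, and compound 3 gives 70500 nM; these two values lie within the scatter of each other. How the cores of compound 3 and compound 2 differ is not broken down here.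

For the measured compounds named here, the one measured step is an at least 1.2-fold higher number from compound 2 to compound 1 (0.11 log units; that floor lies within the scatter), described as carboxy in place of methoxy on an aromatic carbon. The same kind of change leads from compound 3 to the unmeasured compound 4, `CCOC(=O)c1cn(-c2cccc(C(=O)O)c2)nc1CC(C)C`: carboxy in place of methoxy on an aromatic carbon. The two places are not identical: in the measured pair the carboxy stands para to a large group, in the new pair it stands meta to a large group.

For compound 4 the expected step is a 1.4-fold higher number from compound 3 to compound 4 (0.15 log units; within the scatter). That expectation rests on compound 3 with 70500 nM. It also rests on the measured change an at least 1.2-fold higher number from compound 2 to compound 1 (0.11 log units; that floor lies within the scatter). Compound 4 is estimated at 100000 nM, between 60000 nM and 200000 nM, with a fair chance that this assay again reports only a limit.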

Compound 4, half-maximal cytotoxic concentration: 7100 nM
The estimate for compound 4 lay 14-fold (1.15 log units) above the measured number; the measured number lies below the stated range.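

In this assay the new step is a 9.9-fold lower number from compound 3 to compound 4 (1.00 log units; beyond the scatter), with carboxy in place of methoxy on an aromatic carbon, meta to a large group. Set beside the earlier step, the same change does not carry over with the same outcome from the pair of compound 2 and compound 1 to the pair of compound 3 and compound 4: the same change on two cores in this assay, an at least 1.2-fold higher number (0.11 log units; that floor lies within the scatter) from compound 2 to compound 1 and a 9.9-fold lower number (1.00 log units; beyond the scatter) from compound 3 to compound 4, at least 12-fold (1.10 log units) apart, beyond the scatter of two such steps

Compound 1 gives only a limit rather than a number, so the earlier step has a floor and no known size, and one pair on each side does not show whether the place of the carboxy on the ring or something else accounts for the gap, nor does it make a rule for the series: the limit of > 100000 nM in this assay, at which 1 of the 4 values shown sits.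

The compounds shown leave open whether the lower number of compound 4 goes with the carboxy itself, which a primary amide or a nitrile in the same place, meta to a large group, would bear on. Also open, as far as these compounds go, is whether the same step would hold with a longer chain in place of the side chain on the shared core, or with an amine on the aryl ring.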